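This account rests on a few compounds, and the source may have more. Where it says the series, first, only, none or still open, it means among the compounds named here.

Measured compounds in an assay for displacement of a labelled ligand from Adrenergic receptor alpha-1 (Homo sapiens); a lower number here means a stronger inhibitor, a higher number a weaker inhibitor:
Compound 1 `CN(C)c1ccccc1N1CCN(CCCCn2ncc(=O)n(C)c2=O)CC1`: compound 1 gives 350 nM.
Compound 2 `Cn1c(=O)cnn(CCCCN2CCN(c3cccc(O)c3)CC2)c1=O`: compound 2 reaches only > 10000 nM, which is a limit of this assay and not a number.

Compound 2 therefore stands at the weak end of what has been measured, at the limit of > 10000 nM in this assay, at which 1 of the 2 values shown sits. Going by the values given here, the one step that has been followed, an at least 28-fold higher number from compound 1 to compound 2 (1.45 log units; beyond the scatter), shows how much was lost when the 2-(dimethylamino)phenyl group of compound 1 gave way to the 3-hydroxyphenyl group of compound 2.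

Compound 3 `Cn1c(=O)cnn(CCCCN2CCN(c3ccc(F)cn3)CC2)c1=O` is the next compound, and it differs from compound 2 by 5-fluoropyridin-2-yl in place of 3-hydroxyphenyl on an amine nitrogen in a ring. Among the compounds with values here, no measured step covers an exchange of this kind; the only step at hand, from compound 1 to compound 2, concerns a different pair of groups and gives no direct guide. Since compound 2 sits at a limit, a step in either direction from it can only be guessed. Compound 3 is expected to give about 5000 nM in this assay, with a range from 1000 nM to 30000 nM. That estimate corresponds to an at least 2.0-fold lower number from compound 2 to compound 3 (0.30 log units; that floor lies within the scatter), a modest expected gain at best.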

Compound 3, inhibition constant: > 10000 nM
Compound 3 was reported as a limit; the forecaster's own chance of this, stated with the estimate: 50%; at least 2.0-fold (0.30 log units) between middle value and limit.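

In this assay, compound 3 is reported only as a limit, not as a number, and it now shares that limit with compound 2: the limit of > 10000 nM in this assay, at which 2 of the 3 values shown sit.

Placing 5-fluoropyridin-2-yl on the amine nitrogen in the ring, where compound 1 carries 2-(dimethylamino)phenyl, gives an at least 28-fold higher number from compound 1 to compound 3 (1.45 log units; beyond the scatter). The large loss therefore appears with a second, different group, and since 5-fluoropyridin-2-yl has no hydrogen-bond donor, the loss does not depend on the donor of the 3-hydroxyphenyl group. The step between compound 2 and compound 3 cannot be read, because both values are limits, so the two groups cannot be ranked against each other.

The compounds shown leave open how much of the value of compound 1 rests on the dimethylamino group itself, and whether a 2-methoxyphenyl group or an unsubstituted phenyl group on that nitrogen would keep it. They also leave open whether 3-(dimethylamino)phenyl would behave like the 2-(dimethylamino)phenyl group of compound 1.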